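The source may report more compounds than this note shows. Statements on the series, on what has been measured and on what is new or still open speak of the compounds shown alone.

Among the measured compounds shown here, compound 1 `C[C@H](NC(=O)CN(c1nc(Cl)nc2[nH]cnc12)C1CC1)C(=O)OCc1ccccc1` is the stronger of the two compounds measured so far. In a functional assay on the whole organism (Tail, strain ICR) with Mus musculus as the target, in the tail flick test, with a stated time of 60 min, at a dose of 25 umol/kg by the oral route (a higher number here means a stronger effect of the compound at the dose given, a lower number a weaker effect), compound 1 gives 64.3%, the highest of the two numbers recorded. Compound 2 `O=C(OCc1ccccc1)[C@@H]1CCCN1C(=O)CN(c1ncnc2c1ncn2C1CCCCO1)C1CC1` differs from compound 1 at several points. In this assay compound 2 gives 36.7%. This value lies below that of compound 1 by a gap beyond the usual scatter; as the two compounds differ at several points, the gap cannot be tied to any single change.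

Compound 3 `NC(=O)CC[C@H](NC(=O)CN(c1nc(Cl)nc2[nH]cnc12)C1CC1)C(=O)OCc1ccccc1` follows from compound 1 by one change: carbamoylmethyl in place of hydrogen on a saturated chain carbon, two bonds along the chain from an amide-type nitrogen and a carbonyl carbon. The shared core and the cyclopropyl-bearing amide linker are kept.

For the measured compounds named here, no measured pair isolates this kind of change, so its effect is open. A modest downward step is expected for compound 3, estimated as a number 14.3 percentage points lower from compound 1 to compound 3 (beyond the scatter). Compound 3 is therefore estimated at 50% in this assay, with a range from 25% to 75%.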

Compound 3, a percentage reported as activity, at one dose (the size of the read-out at that dose, not a potency): 33.1%
Compound 3: the middle estimate sits 16.9 percentage points above what was measured; the range from low to high includes it.
By their numbers in this assay, from the lowest: compounds 3 and 2 (each within the scatter of the next); then compound 1.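

Carbamoylmethyl in place of hydrogen on this saturated chain carbon gives the first change in the series that can be read on its own: in this assay it brings a number 31.2 percentage points lower from compound 1 to compound 3 (beyond the scatter). The earlier gap between two compounds differing at several points could not be assigned to any one place, whereas this step ties a large loss of effect at the given dose to this single position. The shared core and the cyclopropyl-bearing amide linker stay the same across the step, but nothing available accounts for the drop.

Among the compounds shown here, with only this one group at this position, it remains open whether the loss goes with the added chain or with its carbamoyl end. A plain propyl chain, a carboxylic acid or an amine at the end of the same chain could separate these readings.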